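This account rests on a few compounds, and the source may have more. Where it says the series, first, only, none or still open, it means among the compounds named here.

Measured so far in an assay on CHO cells for displacement of a labelled ligand from adenosine receptor A1 (Homo sapiens), read by scintillation counting, with a stated time of 90 min, in the presence of a further agent that is not named here; a lower number here means a stronger inhibitor, a higher number a weaker inhibitor:

Compound 1 `CCCn1c(=O)[nH]c2nc(-c3ccc(S(=O)(=O)N4CCN(c5ccc(F)cc5)CC4)cc3)[nH]c2c1=O`: > 1000 nM, which is a limit of the assay and not a number.
Compound 2 `CCCn1c(=O)[nH]c2nc(-c3ccc(S(=O)(=O)N(C)C)cc3)[nH]c2c1=O`: 190 nM.
Compound 3 `CCCn1c(=O)[nH]c2nc(-c3ccc(S(=O)(=O)N4CCN(c5cccc(Cl)c5)CC4)cc3)[nH]c2c1=O`: > 1000 nM, again a limit of the assay and not a number.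

All three share one core and differ only in the group attached to the sulfonyl nitrogen. Compound 2 carries a small dimethylamino group and gives a measured number. Compound 1 and compound 3 each carry a piperazine bearing an aryl group, and for both the assay reports only a limit. Going by the values given here, the one step between measured compounds that changes a single place, a step that the two limits leave unreadable from compound 1 to compound 3, cannot be read, because both ends are limits (the limit of > 1000 nM in this assay, at which 2 of the 3 values shown sit). Compound 3 therefore stands at the limit of this assay, where two of the three values sit.

Compound 4 `CCCn1c(=O)[nH]c2nc(-c3ccc(S(=O)(=O)N4CCN(c5cccc(F)c5)CC4)cc3)[nH]c2c1=O` differs from compound 3 in one place: fluoro in place of chloro on an aromatic carbon. Among the compounds with values here, the only measured step that bears on this kind of change, the one from compound 1 to compound 3, is itself unreadable, so no size or direction can be taken from it. A halogen exchange on the aryl ring is a small change, and compound 3 is already at the limit. Compound 4 is therefore expected to stay near that limit, and the expected step that the limit leaves unreadable from compound 3 to compound 4 is none beyond the scatter. The estimate for compound 4 in this assay is 1500 nM, with a range from 400 nM to 6000 nM.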

Compound 4, inhibition constant: > 1000 nM
Compound 4: no number, only a limit (the forecaster's own chance of this, stated with the estimate: 65%); the middle value lies beyond the limit too.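

In this assay compound 4 gives > 1000 nM, a limit of the assay and not a number. The steps to compound 4 from compound 3 and from compound 1 therefore cannot be read: the limit of > 1000 nM in this assay, at which 3 of the 4 values shown sit. Going by these compounds, it stays open whether swapping chloro for fluoro, or 4-fluorophenyl for 3-fluorophenyl, changes binding at all.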